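One aryl swap on a carbonyl carbon

The source may hold more compounds than are shown below. What is called first, only, known or untested is meant among the compounds shown, and "the series" means these compounds.

Compound 1 `COc1ccc(-c2cc(/C=C/C(=O)c3ccc(N)cc3)[nH]n2)cc1`: 97%
Compound 2 `COc1cc(-c2cc(/C=C/C(=O)c3ccc(Cl)c(Cl)c3)[nH]n2)cc(OC)c1OC`: 97%

In a functional assay on U-251 cells (Homo sapiens) for cytotoxicity, read by sulforhodamine B assay, with a stated time of 48 h, tested at 0.01 uM (on this read-out higher numbers stand for a weaker effect at the one concentration tested and lower numbers for a stronger effect), compound 2 gives 97%, level with compound 1 at the digits shown; the two differ by no more than the scatter. Compound 3 `COc1ccc(C(=O)/C=C/c2cc(-c3cc(OC)c(OC)c(OC)c3)n[nH]2)cc1` is not yet measured. Compared with compound 2 it carries 4-methoxyphenyl in place of 3,4-dichlorophenyl on a carbonyl carbon. Among the measured compounds shown here, with only two measured compounds, both weak at this concentration, no step beyond the scatter is expected here. Compound 3 is estimated at 95%, in a range from 85% to 100%. The expected step of a number 2 percentage points lower from compound 2 to compound 3 (within the scatter) is essentially none.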

Compound 3, a percentage reported as activity, at one concentration (the size of the read-out at that concentration, not a potency): 97%
Beside the measured number, compound 3's estimate is 2 percentage points below it; the measured number falls inside the stated range.
By their numbers in this assay, from the lowest: compounds 1, 2 and 3 (each within the scatter of the next).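

In this assay, replacing 3,4-dichlorophenyl with 4-methoxyphenyl on a carbonyl carbon gives no change at the digits printed from compound 2 to compound 3 (within the scatter). Among the compounds shown here, this is the first direct one-place comparison: two chlorine atoms give way to a group with one oxygen and one hydrogen-bond acceptor, and the read-out at this single concentration does not register the exchange. No supporting measurement bears on this result. On these data alone, whether an amine or a carboxylic acid on this carbonyl carbon would move the number remains open. So does how these compounds behave at higher concentrations.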